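This account rests on a few compounds, and the source may have more. Where it says the series, first, only, none or still open, it means among the compounds named here.

Measured so far in an assay on membranes from liver for displacement of a labelled ligand from Sigma intracellular receptor 2 (Rattus norvegicus), read by scintillation counting, with a stated time of 120 min; on this read-out lower numbers stand for stronger inhibition and higher numbers for weaker inhibition:
Compound 1 `Cc1cccc2sc(NC(=O)CCN3CCN(C(C)C)CC3)nc12` gives 1800 nM.
Compound 2 `CCCCN1CCN(CCC(=O)Nc2nc3c(C)cccc3s2)CC1` gives 1200 nM.

Among the measured compounds shown here, compound 2 stands at the lowest of the two numbers, but its nearest neighbour is compound 1, and the only measured step, a 1.5-fold lower number from compound 1 to compound 2 (0.18 log units; within the scatter), lies within the scatter, so the two compounds cannot be told apart on these values. Compound 3 `Cc1cccc2sc(NC(=O)CCN3CCN(CCCN(C)C)CC3)nc12` has not yet been measured in this assay. It differs from compound 2 by dimethylamino in place of methyl on a saturated chain carbon, three bonds along the chain from an amine nitrogen in a ring. For the measured compounds named here, no measured step concerns a dimethylamino group; the only step that bears on compound 3 at all is a 1.5-fold lower number from compound 1 to compound 2 (0.18 log units; within the scatter), which changed the substituent on the same ring amine and stayed within the scatter. With nothing more to go on, the step of no change at the digits printed from compound 2 to compound 3 (within the scatter) is expected to stay within the scatter as well. The estimate for compound 3 in this assay is therefore 1200 nM, within 400 nM to 3500 nM.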

Compound 3, inhibition constant: > 1000 nM
Compound 3 was reported as a limit; the forecaster's own chance of this, stated with the estimate: 5%; the middle value does not contradict the limit.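

Compound 3 is reported only as a limit, not as a number: the limit of > 1000 nM in this assay, at which 1 of the 3 values shown sits. Among the compounds shown here, no step from compound 1 or compound 2 to compound 3 can be read from it. The compounds shown leave open whether 3-(dimethylamino)propyl on the ring amine changes the value at all.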